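A few compounds are considered here, and "the series" means these few. Any claim that something is new, unique, unknown or untested is made for them only; others in the source may bear on it.

Measured in a functional assay on HCT-116 cells (Homo sapiens) for cytotoxicity, read by MTT assay, with a stated time of 72 h; a lower number here means a stronger inhibitor, a higher number a weaker inhibitor:
- Compound 1 `CS(=O)(=O)Oc1c(C(=O)NCc2ccc(F)cc2)nc(Br)c2cccnc12`: > 20000 nM (a limit)
- Compound 2 `N[C@H]1CC[C@H](Nc2c(C(=O)NCc3ccc(F)cc3)nc(Br)c3cccnc23)CC1`: 7000 nM
- Compound 3 `C[C@H](Nc1c(C(=O)NCc2ccc(F)cc2)nc(Br)c2cccnc12)c1ccccc1`: > 20000 nM (a limit)

Compound 3 stands at a limit, > 20000 nM. This is the limit of > 20000 nM in this assay, at which 2 of the 3 values shown sit. Compound 4 `O=C(NCc1ccc(F)cc1)c1nc(Br)c2cccnc2c1N1CCNCC1` has not yet been measured. It carries piperazin-1-yl in place of (1-phenylethyl)amino on an aromatic carbon, para to a bromo group: piperazin-1-yl in place of (1-phenylethyl)amino on an aromatic carbon.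

Among the measured compounds shown here, two measured steps bear on this change. One is an at least 2.8-fold higher number from compound 2 to compound 3 (0.45 log units; beyond the scatter), and the other is an at least 2.8-fold lower number from compound 1 to compound 2 (0.45 log units; beyond the scatter). Both lie beyond the scatter. For the measured compounds named here, the closer guide is compound 2, which also has a non-aromatic ring in this region and gives the only number so far, 7000 nM. A modest move to a lower number than compound 3 is therefore expected, though compound 4 may still reach the limit. The estimated step is an at least 2.2-fold lower number from compound 3 to compound 4 (0.34 log units; beyond the scatter). For compound 4 the expected value is 9000 nM, with an estimated range from 3000 nM to 25000 nM.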

Compound 4, half-maximal inhibitory concentration: > 10000 nM
Compound 4 was reported as a limit (the forecaster's own chance of this, stated with the estimate: 30%); middle value at least 1.1-fold (0.04 log units) away from the limit.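

Compound 4 gives no number in this assay, only a limit, so piperazin-1-yl at this position joins the values that lie outside the measured range: the limit of > 10000 nM in this assay, at which 1 of the 4 values shown sits. Set against the one number available, the change reads as an at least 1.4-fold higher number from compound 2 to compound 4 (0.15 log units; that floor lies within the scatter), which leaves open whether piperazin-1-yl truly falls behind (4-aminocyclohexyl)amino, yet shows that a non-aromatic ring with nitrogen at this position does not by itself give a measured value. The steps from compound 1 and from compound 3 to compound 4 cannot be read, and compound 2 remains the only one of the four with a number, 7000 nM.

Where compound 4 truly lies relative to compound 2 stays open. So does whether morpholin-4-yl, or a primary amine on a longer chain such as 3-aminopropylamino, would give a number in this assay.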